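Shortening the hydroxyalkyl sulfonamide chain on compound 2

A few compounds are considered here, and "the series" means these few. Any claim that something is new, unique, unknown or untested is made for them only; others in the source may bear on it.

Compound 2 `CC[C@@H]1C(=O)N(C)c2cnc(Nc3ccc(S(=O)(=O)NCCCO)cc3)nc2N1C1CCCC1` and compound 1 `CCCNS(=O)(=O)c1ccc(Nc2ncc3c(n2)N(C2CCCC2)[C@H](CC)C(=O)N3C)cc1` share one core and differ only in the chain on the sulfonamide nitrogen. In a functional assay on Huh-7 cells (Homo sapiens) for antiproliferative activity, read by CCK-8 assay, with a stated time of 72 h (a lower number here means a stronger inhibitor of growth, a higher number a weaker inhibitor of growth), compound 2 gives 262 nM, and compound 1 gives 278 nM in this assay, so the two numbers cannot be told apart within the scatter. Within the data shown here, the one measured step, a 1.1-fold lower number from compound 1 to compound 2 (0.03 log units; within the scatter), shows that adding a hydroxy three bonds along the chain from the sulfonamide nitrogen left the number essentially unchanged.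

Compound 3 `CC[C@@H]1C(=O)N(C)c2cnc(Nc3ccc(S(=O)(=O)NCCO)cc3)nc2N1C1CCCC1` carries the next change: hydroxy in place of hydroxymethyl on a saturated chain carbon, two bonds along the chain from a sulfonamide nitrogen. Among the measured compounds shown here, the only step that bears on it is the one from compound 1 to compound 2, which was within the scatter, and it suggests that what sits at the end of this chain, or how long the chain is, matters little for this assay. A step of a 1.0-fold higher number from compound 2 to compound 3 (0.01 log units; within the scatter) is therefore expected, that is, none beyond the scatter. Compound 3 is estimated at 270 nM in this assay, within a range from 130 nM to 560 nM.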

Compound 3, concentration for 50% growth inhibition: 278 nM
Compound 3: the middle estimate sits 1.0-fold (0.01 log units) below what was measured, and the stated range covers the measured number.
By their numbers in this assay, from the lowest: compounds 2, 1 and 3 (each within the scatter of the next).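

In this assay, going from 3-hydroxypropyl to 2-hydroxyethyl on the sulfonamide nitrogen gives a 1.1-fold higher number from compound 2 to compound 3 (0.03 log units; within the scatter), so with the hydroxy kept, this chain can lose one carbon without the number leaving the scatter. With hydroxy in place of methyl on a saturated chain carbon, two bonds along the chain from a sulfonamide nitrogen, the reading is no change at the digits printed from compound 1 to compound 3 (within the scatter), which means the propyl, 3-hydroxypropyl and 2-hydroxyethyl chains cannot be told apart at this position, and the earlier finding for the hydroxy now holds at two chain lengths rather than one. Nothing among the data available explains this flat result.

The compounds shown leave open whether an amine or a carboxylic acid in place of the hydroxy, or a longer chain such as a 5-carbon hydroxyalkyl group, would stay within the scatter or move the number beyond it. They also leave open whether a sulfonamide nitrogen bearing only hydrogen, with no chain at all, would read like these three compounds on the shared core.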